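A Fluoro Swap in a Flat Series

The source may hold more compounds than are shown below. What is called first, only, known or untested is meant among the compounds shown, and "the series" means these compounds.

In a functional assay, read by Griess assay, with a stated time of 2.5 h (a lower number here means a stronger inhibitor, a higher number a weaker inhibitor), compound 1 (`COc1ccc(C(=O)/C=C/c2cc(OC)c(OC)cc2OC)cc1`) gives 2.07 ug/mL while compound 2 (`COc1cc(OC)c(OC)cc1/C=C/C(=O)c1ccccc1`) gives 2.01 ug/mL and compound 3 (`COc1cc(OC)c(OC)cc1/C=C/C(=O)c1ccc(C)cc1`) gives 2.18 ug/mL, which leaves compound 3 level with the other two. Compound 4 (`COc1cc(OC)c(OC)cc1/C=C/C(=O)c1ccc(F)cc1`) carries fluoro in place of methyl on an aromatic carbon, para to a large group (fluoro in place of methyl on an aromatic carbon). Swaps among methoxy, hydrogen and methyl on that carbon gave only small steps (a 1.0-fold lower number from compound 1 to compound 2 (0.01 log units; within the scatter); a 1.1-fold higher number from compound 1 to compound 3 (0.02 log units; within the scatter); a 1.1-fold higher number from compound 2 to compound 3 (0.04 log units; within the scatter)), all within the scatter. Among the compounds with values here, no measured compound carries fluoro, so this remains an extrapolation, and no step beyond the scatter is expected in this assay. The estimated step is small (a 1.0-fold lower number from compound 3 to compound 4 (0.02 log units; within the scatter)). The expected value for compound 4 is 2.1 ug/mL, with an estimated range from 1.2 ug/mL to 3.5 ug/mL.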

Compound 4, half-maximal inhibitory concentration: 1.96 ug/mL
Estimate against measurement, compound 4: 1.1-fold (0.03 log units) above; low and high end bracket the measured number.
By their numbers in this assay, from the lowest: compounds 4, 2, 1 and 3 (each within the scatter of the next).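

Fluoro on this aromatic carbon, para to a large group, also stays within the scatter in this assay, whether it replaces methyl (a 1.1-fold lower number from compound 3 to compound 4 (0.05 log units; within the scatter)), hydrogen (a 1.0-fold lower number from compound 2 to compound 4 (0.01 log units; within the scatter)) or methoxy (a 1.1-fold lower number from compound 1 to compound 4 (0.02 log units; within the scatter)). A halogen therefore joins the three earlier groups without separating from them, so all four compounds read as level at this position. Nothing available explains why this position tolerates these swaps. As far as these compounds go, whether an amine or a carboxylic acid on this carbon would move the number beyond the scatter stays open. So does the effect of changes elsewhere on the shared core.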